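A few compounds are considered here, and "the series" means these few. Any claim that something is new, unique, unknown or untested is made for them only; others in the source may bear on it.

Measured so far in a functional assay on HEK293 cells for antagonist activity at Oxytocin receptor (Homo sapiens), read by calcium flux, with a stated time of 10 min, in the presence of a further agent that is not named here; a lower number here means a stronger inhibitor, a higher number a weaker inhibitor:
compound 1 `COCc1nnc(N2CC3(CCc4cc(F)ccc4O3)C2)n1-c1ccc(OC)nc1` gives 401 nM
compound 2 `COCc1nnc(N2CCC(c3ccc(F)cc3Cl)CC2)n1-c1ccc(OC)nc1` gives 10 nM
compound 3 `COc1ccc(-n2c(COC3CCOCC3)nnc2N2C[C@@H]3C[C@]3(c3ccc(F)cc3Cl)C2)cn1` gives 826 nM

Compound 3 carries the highest number of the three in this assay. The nearest is compound 1, and that gap already lies beyond the scatter; the gap to compound 2 is very much larger. Compound 2 thus stands apart from both ring-fused cores shown here.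

Compound 4 `COc1ccc(-n2c(C(F)F)nnc2N2C[C@@H]3C[C@]3(c3ccc(F)cc3Cl)C2)cn1` differs from compound 3 in one place: difluoromethyl in place of ((oxan-4-yl)oxy)methyl on an aromatic carbon. Within the data shown here, no measured pair isolates this change. Compounds 1 and 2 carry a methoxymethyl at the corresponding carbon of their own cores, but those cores differ from the core of compound 3, so their values do not settle the effect of the exchange.

With nothing to anchor it, the step of a 1.7-fold lower number from compound 3 to compound 4 (0.22 log units; within the scatter) is expected to be modest, with no firm direction, and may well fall within the scatter. Compound 4 is therefore estimated at 500 nM in this assay, with a range from 120 nM to 2000 nM.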

Compound 4, half-maximal inhibitory concentration: 52 nM
The estimate for compound 4 lay 9.6-fold (0.98 log units) above the measured number; measured number below the stated range.
By their numbers in this assay, from the lowest: compound 2; then compound 4; then compound 1; then compound 3.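

In this assay this carbon of the five-membered aromatic ring with 3 nitrogen proves far from neutral: difluoromethyl in place of ((oxan-4-yl)oxy)methyl gives a 16-fold lower number from compound 3 to compound 4 (1.20 log units; beyond the scatter), a step well beyond the scatter. Among these compounds, no earlier pair isolated this position, and the result now shows that the high number of compound 3 does not belong to its core alone. No measured evidence accounts for the size of this step.

On these data alone, whether the step reflects the loss of ((oxan-4-yl)oxy)methyl or the arrival of difluoromethyl stays open, with only these two groups compared on this core. A plain methyl, a trifluoromethyl or a methoxymethyl at the same carbon of this core would help separate the two readings, and an amine would extend the comparison.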